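Spirocyclic lactam isomers on the shared core

The source may hold more compounds than are shown below. What is called first, only, known or untested is meant among the compounds shown, and "the series" means these compounds.

Among the compounds with values here, compound 2 `Cn1ncc2cc(-c3cnc4[nH]ccc4c3N3CC4(CNC(=O)C4)C3)ccc21` gives 698 nM in an assay on cells for binding affinity to Cyclin-C/Cyclin-dependent kinase 19 (Homo sapiens), read by LanthaScreen (on this read-out lower numbers stand for stronger inhibition and higher numbers for weaker inhibition), and is the only compound of the series with a number in this assay; compound 1 `Cn1ncc2cc(-c3cnc4sccc4c3N3CCC4(CCNC4=O)CC3)ccc21` stands there as "not determined" (no result reported). Compound 3 `Cn1ncc2cc(-c3cnc4[nH]ccc4c3N3CC4(CCNC4=O)C3)ccc21` differs from compound 2 by a group of 9 heavy atoms (6 carbon, 2 nitrogen, 1 oxygen; one four-membered non-aromatic ring with 1 hetero atom, one five-membered non-aromatic ring with 1 hetero atom) in place of a group of 9 heavy atoms (6 carbon, 2 nitrogen, 1 oxygen; one four-membered non-aromatic ring with 1 hetero atom, one five-membered non-aromatic ring with 1 hetero atom), on an aromatic carbon, the two having the same atoms joined differently. Within the data shown here, no measured pair in this assay shows the size of such a rearrangement, so no step beyond the usual scatter is assumed in either direction. Compound 3 is therefore expected close to compound 2, estimated at 700 nM within a range of 250 nM to 2000 nM. The expected step of a 1.0-fold higher number from compound 2 to compound 3 (0.00 log units; within the scatter) is essentially none.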

Compound 3, half-maximal inhibitory concentration: 426 nM
Compound 3: the middle estimate sits 1.6-fold (0.22 log units) above what was measured; the measured number falls inside the stated range.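

Within the data shown here, the step of a 1.6-fold lower number from compound 2 to compound 3 (0.21 log units; within the scatter) in this assay is the first measured pair, and it comes from joining the same atoms differently on the aromatic carbon opposite the ring nitrogen. At this position, the two spirocyclic lactam isomers cannot be told apart. No measurement on hand bears on the result.

Still open, as far as these compounds go, is how the read-out answers at this position to a group without the lactam, such as a primary amine or a carboxylic acid.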